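The compounds below may be only part of what the source reports. "The series", "measured", "known", "first", "only" and "open" are said of these compounds alone.

Series notes, pendant aryl variation on the shared core. In a functional assay on Ehrlich cells (Mus musculus) for cytotoxicity, tested at 50 ug/mL (on this read-out lower numbers stand for a weaker effect and higher numbers for a stronger effect at the one concentration tested), compound 1 `COc1cc(N2C(N)=C(C#N)C(c3cccc([N+](=O)[O-])c3)C3=C2CC(C)(C)CC3=O)cc(OC)c1OC` gives 30%. In this assay compound 2 `COc1ccccc1C1C(C#N)=C(N)N(c2cc(OC)c(OC)c(OC)c2)C2=C1C(=O)CC(C)(C)C2` gives 70%, and in this assay compound 3 `COc1cc(N2C(N)=C(C#N)C(c3ccc(O)cc3)C3=C2CC(C)(C)CC3=O)cc(OC)c1OC` gives 90%. Compound 3 thus stands highest of the three numbers, with compound 2 nearest and compound 1 furthest; the steps of a number 60 percentage points higher from compound 1 to compound 3 (beyond the scatter) and a number 20 percentage points higher from compound 2 to compound 3 (beyond the scatter) both lie beyond the scatter, as does a number 40 percentage points higher from compound 1 to compound 2 (beyond the scatter).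

Compound 4 `COc1ccc(C2C(C#N)=C(N)N(c3cc(OC)c(OC)c(OC)c3)C3=C2C(=O)CC(C)(C)C3)cc1` differs from compound 3 by methyl in place of hydrogen on an oxygen on an aromatic ring. Among the compounds with values here, no measured step exchanges hydrogen for methyl on this oxygen directly. The nearest comparison is a number 20 percentage points higher from compound 2 to compound 3 (beyond the scatter), in which a 2-methoxyphenyl rather than a 4-methoxyphenyl stands below the 4-hydroxyphenyl by a modest amount; the step of a number 60 percentage points higher from compound 1 to compound 3 (beyond the scatter) concerns a 3-nitrophenyl and bears less on the present change. A modest downward step in this assay is therefore the expectation for compound 4, though one that might not clear the scatter, since the methoxyphenyl of compound 2 is not the 4-methoxyphenyl of compound 4. Compound 4 is expected to give 75%, with a range from 55% to 95%. The expected step is estimated as a number 15 percentage points lower from compound 3 to compound 4 (beyond the scatter).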

Compound 4, a percentage reported as activity, at one concentration (the size of the read-out at that concentration, not a potency): 11%
Compound 4: the middle estimate sits 64 percentage points above what was measured, outside the stated range (below it).
By their numbers in this assay, from the lowest: compound 4; then compound 1; then compound 2; then compound 3.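

In this assay, within the data shown here, this is the first direct exchange on the oxygen on an aromatic ring, and methyl in place of hydrogen gives a number 79 percentage points lower from compound 3 to compound 4 (beyond the scatter), the largest step, so that one added carbon outweighs every exchange of the whole pendant aryl group seen so far. The two methoxy isomers also part widely, with a number 59 percentage points lower from compound 2 to compound 4 (beyond the scatter), so a methoxy group on the pendant phenyl does not set the read-out by its presence alone, and with a number 19 percentage points lower from compound 1 to compound 4 (beyond the scatter) the 4-methoxyphenyl falls under even the 3-nitrophenyl and leaves compound 4 lowest of the four. Nothing at hand explains the size of these steps or the order of the four compounds.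

On these data alone, it remains open whether the read-out depends on the free hydroxy group specifically or would survive another group in its place, which a 4-aminophenyl or a 4-ethoxyphenyl on the same core would help to separate. As far as these compounds go, the read-out also comes from a single concentration, so how these compounds would rank in potency stays unknown.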